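The source may hold more compounds than are shown below. What is called first, only, known or untested is meant among the compounds shown, and "the series" means these compounds.

Working notes on the series. The common core carries a substituted thiophene methylamine, and the compounds are compared in an ADME assay on MDCK cells (Canis lupus familiaris) for cytotoxicity, read by microscopy, with a stated time of 48 h; a lower number here means that less compound is tolerated, a higher number that more compound is tolerated.

Compound 1 `C[C@H]1[C@H](NCc2sccc2C2CCCC2)C[C@H]2C[C@@H]1C2(C)C` gives 12500 nM in this assay. Compound 2 `C[C@H]1[C@H](NCc2cc(-c3ccsc3)cs2)C[C@H]2C[C@@H]1C2(C)C` gives 25000 nM in this assay, which is the highest of the two numbers shown; the nearest is compound 1, whose value sits within the scatter of compound 2, so no order between the two can be stated. Compound 3 `Cc1csc(CN[C@@H]2C[C@H]3C[C@@H]([C@H]2C)C3(C)C)n1` is a separate case: in this assay compound 3 gives > 100000 nM, which is a limit of the assay and not a number, as recorded in the limit of > 100000 nM in this assay, at which 1 of the 3 values shown sits.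

Compound 4 `C[C@H]1[C@H](NCc2cc(C3CCCC3)cs2)C[C@H]2C[C@@H]1C2(C)C` is not yet measured in this assay. Relative to compound 2, the change is cyclopentyl in place of thiophen-3-yl on an aromatic carbon. Among the compounds with values here, no measured pair differs in only this place, so the size of the step cannot be read from the data. Compound 1 carries a cyclopentyl on its thiophene as well and gives 12500 nM, a value within the scatter of compound 2, so for compound 4 no step beyond the scatter is expected in either direction, and a 1.7-fold lower number from compound 2 to compound 4 (0.22 log units; within the scatter) is the expected step. The estimate for compound 4 in this assay is 15000 nM, with a range from 6000 nM to 50000 nM.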

Compound 4, minimum cytotoxic concentration: 1560 nM
Compound 4: the middle estimate sits 9.6-fold (0.98 log units) above what was measured; measured number outside the range, below it.
By their numbers in this assay, from the lowest: compound 4; then compounds 1 and 2 (each within the scatter of the next). At a limit, above all of these: compound 3.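

Within the data shown here, the pair gives the first step beyond the scatter: in this assay, cyclopentyl in place of thiophen-3-yl gives a 16-fold lower number from compound 2 to compound 4 (1.20 log units; beyond the scatter). The position, an aromatic carbon two ring bonds from the ring sulfur and two ring bonds from the ring atom that bears a large group, is therefore sensitive to the identity of its substituent, with less compound tolerated when cyclopentyl stands there. The two groups have the same count of 5 heavy atoms, so that count alone does not set the outcome; they differ in aromatic against non-aromatic ring and in the ring sulfur, and nothing shown gives a cause for the step.

The compounds shown leave open whether the ring's aromatic character or its sulfur goes with the higher number, a question that a phenyl ring or a furan ring at this carbon would address. They also leave open how an open pentyl chain or a ring carrying an amine or a carboxylic acid would read at this position, and whether the same exchange gives a step of this size elsewhere on the thiophene.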